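Amino in Place of Hydroxy on the Aryl Ketone

The compounds below may be only part of what the source reports. "The series", "measured", "known", "first", "only" and "open" are said of these compounds alone.

Compound 1 `Cn1cccc1C(=O)/C=C/c1ccc2c(c1)B(O)OC2`: in a functional assay on MDA-MB-231 cells (Homo sapiens) for cytotoxicity, read by MTT assay, with a stated time of 48 h (a lower number here means a stronger inhibitor, a higher number a weaker inhibitor), compound 1 gives only a limit, > 100000 nM.
Compound 2 `O=C(/C=C/c1ccc2c(c1)B(O)OC2)c1cccc(O)c1`: in this assay compound 2 gives 2700 nM.

Compound 2 holds the only number shown; the other value is a limit, namely (the limit of > 100000 nM in this assay, at which 1 of the 2 values shown sits). For the measured compounds named here, the single measured step, an at least 37-fold lower number from compound 1 to compound 2 (1.56 log units; beyond the scatter), concerns the group on the carbonyl carbon. Compound 3 `Nc1cccc(C(=O)/C=C/c2ccc3c(c2)B(O)OC3)c1` differs from compound 2 by amino in place of hydroxy on an aromatic carbon. Going by the values given here, no measured step touches this exchange, so compound 3 is expected to change little, a 1.5-fold higher number from compound 2 to compound 3 (0.17 log units; within the scatter). Compound 3 is estimated at 4000 nM, within 1200 nM to 15000 nM.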

Compound 3, half-maximal inhibitory concentration: 3200 nM
For compound 3 the middle estimate is 1.3-fold (0.10 log units) above the measured one; low and high end bracket the measured number.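

In this assay, amino in place of hydroxy on an aromatic carbon gives a 1.2-fold higher number from compound 2 to compound 3 (0.07 log units; within the scatter), so the two groups cannot be told apart at this position. The large step from the 1-methyl-1H-pyrrol-2-yl ketone, an at least 31-fold lower number from compound 1 to compound 3 (1.49 log units; beyond the scatter), shows that the difference from compound 1 does not depend on hydroxy, since 3-aminophenyl carries it as well as 3-hydroxyphenyl. Compound 1 gives only a limit: the limit of > 100000 nM in this assay, at which 1 of the 3 values shown sits.

Still open, from the compounds shown here alone, is whether a methoxy group, a carboxylic acid or plain hydrogen at this position would match compound 2 and compound 3.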